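The source may hold more compounds than are shown below. What is called first, only, known or untested is meant among the compounds shown, and "the series" means these compounds.

In an ADME assay on HEK293 cells (Homo sapiens) for inhibition, read by MTT assay, with a stated time of 48 h (on this read-out lower numbers stand for stronger inhibition and higher numbers for weaker inhibition), compound 1 (`CCc1ccc(-c2nc3ccccn3c2Sc2ccccc2)cc1`) gives only a limit, > 100000 nM, so no number is available for it. Compound 2 (`c1ccc(Sc2c(-c3ccccc3)nc3ccc(-c4ccccc4)cn23)cc1`) also gives only a limit, > 100000 nM. Among the measured compounds shown here, the two compounds therefore sit at the same limit, (the limit of > 100000 nM in this assay, at which 2 of the 2 values shown sit), and no measured step between compounds is available to guide a prediction.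

Compound 3 (`CSc1ccc(-c2nc3ccccn3c2Sc2ccccc2)cc1`) keeps the core of compound 1 but has methylsulfanyl in place of ethyl on an aromatic carbon, para to a large group, (methylsulfanyl in place of ethyl on an aromatic carbon). The change is a swap of 4-ethylphenyl for 4-(methylsulfanyl)phenyl. The expected step of a number no higher from compound 1 to compound 3 (the limit leaves the size open) is no larger than the scatter, in neither direction, and this expectation rests only on the shared limit, (the limit of > 100000 nM in this assay, at which 2 of the 2 values shown sit). The assay may well report only a limit again. For compound 3 the estimated value is 100000 nM, with an expected range from 40000 nM to 200000 nM.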

Compound 3, half-maximal inhibitory concentration: > 100000 nM
Compound 3 ended at the assay's limit; the forecaster's own chance of this, stated with the estimate: 75%; the middle value lies on the limit itself.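

Compound 1 and compound 3 both end at a limit, and the step between them cannot be read: the limit of > 100000 nM in this assay, at which 3 of the 3 values shown sit. The compounds shown leave open whether methylsulfanyl in place of ethyl changes anything in this assay, and what actual value any of them would have.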